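This account rests on a few compounds, and the source may have more. Where it says the series, first, only, none or still open, it means among the compounds named here.

Measured so far in a functional assay on MCF7 cells (Homo sapiens) for antiproliferative activity, read by MTT assay, with a stated time of 72 h; a lower number here means a stronger inhibitor, a higher number a weaker inhibitor:
compound 1 `Cc1cccc(N(C)S(=O)(=O)C2CC3OC2C(c2ccc(NC(=O)CCCCCCC(=O)O)cc2)=C3c2ccc(O)cc2)c1` gives 30200 nM
compound 2 `CCN(c1cccc(OC)c1)S(=O)(=O)C1CC2OC1C(c1ccc(NC(=O)CCCCCCC(=O)O)cc1)=C2c1ccc(O)cc1` gives 37400 nM

Among the compounds with values here, compound 2 at 37400 nM lies within the scatter of compound 1 (30200 nM), the only other measured compound, so it has no separate standing. Next is compound 3 `CCN(c1ccc(Cl)cc1)S(=O)(=O)C1CC2OC1C(c1ccc(NC(=O)CCCCCCC(=O)O)cc1)=C2c1ccc(O)cc1`, with 4-chlorophenyl in place of 3-methoxyphenyl on a sulfonamide nitrogen as the change. Within the data shown here, the one measured step bearing on this is a 1.2-fold higher number from compound 1 to compound 2 (0.09 log units; within the scatter) and it also exchanged the aromatic group on that nitrogen. Among the measured compounds shown here, no measured compound carries 4-chlorophenyl, so this evidence is thin. The step expected in this assay is therefore a 1.1-fold lower number from compound 2 to compound 3 (0.05 log units; within the scatter) and no larger than the scatter. Compound 3 is estimated at 33000 nM (expected range 15000 nM to 70000 nM).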

Compound 3, half-maximal inhibitory concentration: 22100 nM
Compound 3: middle estimate off by 1.5-fold (0.17 log units), on the high side, and the stated range covers the measured number.
By their numbers in this assay, from the lowest: compounds 3, 1 and 2 (each within the scatter of the next).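

In this assay, replacing 3-methoxyphenyl with 4-chlorophenyl on the sulfonamide nitrogen while keeping the ethyl group gives a 1.7-fold lower number from compound 2 to compound 3 (0.23 log units; within the scatter), and the wider exchange on the sulfonyl sulfur gives a 1.4-fold lower number from compound 1 to compound 3 (0.14 log units; within the scatter). This position therefore accepts a chlorine-bearing phenyl ring in place of the methoxy-bearing one, with the hydrogen-bond acceptor of the leaving group gone, and all three compounds remain within the scatter of one another. No measurement available here accounts for these small steps.

Going by these compounds, whether an amine or a carboxylic acid on this phenyl ring would move the number beyond the scatter remains open. Also open, on these data alone, is what a longer chain in place of the ethyl group on the sulfonamide nitrogen, or a saturated cyclohexyl ring in place of the phenyl ring, would do.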